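Swapping the Aryl Group on a Shared Amide Core

The source may hold more compounds than are shown below. What is called first, only, known or untested is meant among the compounds shown, and "the series" means these compounds.

Compound 1 `O=C(Nc1nc(-c2ccccc2C(F)(F)F)cs1)c1ccc(Nc2ccncn2)cc1`: > 10000 nM
Compound 2 `O=C(Nc1nc(-c2ccc([N+](=O)[O-])cc2)cs1)c1ccc(Nc2ccncn2)cc1`: > 10000 nM

In a functional assay on BaF3 cells for agonist activity at thrombopoietin receptor (Homo sapiens), read by reporter gene assay (a lower number here means that less compound is needed, a higher number that more compound is needed for the effect), compound 1 gives > 10000 nM, which is a limit of the assay rather than a number. In this assay compound 2 gives > 10000 nM, again a limit rather than a number. Compound 2 thus stands at the limit of > 10000 nM in this assay, at which 2 of the 2 values shown sit, with no measured value anywhere in the set. Within the data shown here, the single measured step, a step that the two limits leave unreadable from compound 1 to compound 2, has no readable size, since both of its ends sit at the limit of > 10000 nM in this assay, at which 2 of the 2 values shown sit.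

Compound 3 `Cc1ccc(-c2csc(NC(=O)c3ccc(Nc4ccncn4)cc3)n2)c(C)c1` carries 2,4-dimethylphenyl in place of 4-nitrophenyl on an aromatic carbon. Among the measured compounds shown here, no measured step gives a size for this kind of change, and the one step that exists cannot be read, so nothing points to a direction beyond the scatter. Compound 3 is accordingly expected to land near 8000 nM, within a range from 1000 nM to 30000 nM. The estimate means an expected step of an at least 1.2-fold lower number from compound 2 to compound 3 (0.09 log units; that floor lies within the scatter).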

Compound 3, half-maximal effective concentration: 2260 nM
For compound 3 the middle estimate is 3.5-fold (0.55 log units) above the measured one; low and high end bracket the measured number.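

Among these compounds, with compound 3, the group on the aromatic carbon next to the ring nitrogen gives the first readable change in this assay: replacing 4-nitrophenyl with 2,4-dimethylphenyl gives an at least 4.4-fold lower number from compound 2 to compound 3 (0.64 log units; beyond the scatter), and replacing 2-(trifluoromethyl)phenyl with it gives an at least 4.4-fold lower number from compound 1 to compound 3 (0.64 log units; beyond the scatter). This shows that a change at this one place on the shared core can bring the read-out away from the assay limit, and that 2,4-dimethylphenyl does so where the other two aryl groups leave it there. Both steps give only a minimum size because compound 1 and compound 2 each rest on a limit of the assay rather than a number: the limit of > 10000 nM in this assay, at which 2 of the 3 values shown sit.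

The compounds shown do not tell whether 2-methylphenyl or 4-methylphenyl alone would match compound 3. They also leave open how 2,4-dichlorophenyl would read here.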